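Anilino for Chlorophenyl on a Weakly Active Core

The source may report more compounds than this note shows. Statements on the series, on what has been measured and on what is new or still open speak of the compounds shown alone.

Of the compounds shown here, three with a shared core have been tested in a functional assay on the whole organism (stomach) with Rattus norvegicus as the target; a higher number here means that more compound is needed for the effect, a lower number that less compound is needed. Compound 1 `C/N=C(/NC#N)NCCCCn1nc(C)ccc1=O` gives only a limit of the assay, > 100 mg/kg. Compound 3 `C/N=C(/NC#N)NCCCCCn1nc(-c2ccccc2)cc(C)c1=O` likewise gives only a limit, > 100 mg/kg. Within the data shown here, compound 2 `C/N=C(/NC#N)NCCCCn1nc(-c2ccc(Cl)cc2)ccc1=O`, in which 4-chlorophenyl replaces the methyl of compound 1, is the single compound with a number: in this assay compound 2 gives 100 mg/kg. The step of a number no higher from compound 1 to compound 2 (the limit leaves the size open) is a number no higher, with a size that cannot be read. Among the measured compounds shown here, because of the limit of > 100 mg/kg in this assay, at which 2 of the 3 values shown sit, the one number in hand stands right at the edge of what the assay reports.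

Compound 4 `C/N=C(/NC#N)NCCCCn1nc(Nc2ccccc2)ccc1=O` has not yet been measured. It differs from compound 2 in one place: anilino in place of 4-chlorophenyl on an aromatic carbon. For the measured compounds named here, no measured step exchanges these two groups, so the only guide is that the measured compounds gather around the limit. Compound 4 is therefore expected to give about 100 mg/kg, between 30 mg/kg and 300 mg/kg, with a fair chance that only a limit is reported. The step of no change at the digits printed from compound 2 to compound 4 (within the scatter) is accordingly estimated to be none beyond the scatter.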

Compound 4, dose for half-maximal effect: > 100 mg/kg
Compound 4: a limit, no number; the forecaster's own chance of this, stated with the estimate: 50%; the middle value sits exactly at the limit.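

The exchange gives a number no lower from compound 2 to compound 4 (the limit leaves the size open): at this aromatic carbon, anilino, with its added hydrogen-bond donor and acceptor, brings no lower number than 4-chlorophenyl. Compound 2 therefore remains the only compound here with a real number, and the other steps among these compounds, including the one from methyl to anilino, cannot be read. Little can be said about the size of any change at this position because the series sits almost entirely at the edge of what this assay reports: the limit of > 100 mg/kg in this assay, at which 3 of the 4 values shown sit.

The compounds shown leave open whether a 4-methoxyphenyl or a benzylamino group at this carbon would give a clearly lower number than compound 2. They also leave open what a longer chain would do on compound 2, with its 4-chlorophenyl group kept in place.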